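The source may report more compounds than this note shows. Statements on the series, on what has been measured and on what is new or still open speak of the compounds shown alone.

Working notes on the series. In a functional assay on PC-3 cells (Homo sapiens) for inhibition, read by MTT assay, with a stated time of 48 h (a higher number here means a weaker inhibitor, a lower number a stronger inhibitor), compound 1 `COc1ccc(-c2nc3cc(/C=C4\SC(=O)NC4=O)ccc3[nH]2)cc1OC` gives 8720 nM. Compound 2 `COc1cc(OC)c(-c2nc3cc(/C=C4\SC(=O)NC4=O)ccc3[nH]2)cc1OC` gives 6320 nM in this assay; of the two numbers measured it stands nearest compound 1, and the step of a 1.4-fold lower number from compound 1 to compound 2 (0.14 log units; within the scatter) lies within the scatter. Compound 3 `COc1cc(OC)c(-c2nc3cc(/C=C4\SC(=O)N(CC(=O)N5CCOCC5)C4=O)ccc3[nH]2)cc1OC` differs from compound 2 by ((morpholin-4-yl)carbonyl)methyl in place of hydrogen on an amide-type nitrogen in a ring. For the measured compounds named here, the single measured step concerns an aromatic carbon and bears not at all on the ring nitrogen, so no change beyond the scatter is expected, an expected step of a 1.1-fold lower number from compound 2 to compound 3 (0.02 log units; within the scatter). Compound 3 is estimated at 6000 nM, with a range from 2000 nM to 20000 nM.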

Compound 3, half-maximal inhibitory concentration: 11700 nM
Beside the measured number, compound 3's estimate is 2.0-fold (0.29 log units) below it, within the range that was stated.
By their numbers in this assay, from the lowest: compounds 2, 1 and 3 (each within the scatter of the next).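

In this assay, ((morpholin-4-yl)carbonyl)methyl in place of hydrogen on the amide-type nitrogen in a ring gives a 1.9-fold higher number from compound 2 to compound 3 (0.27 log units; within the scatter). This position therefore takes a group with a six-membered non-aromatic ring, and the loss of the amide hydrogen leaves the step inside the scatter. Nothing available explains the size of this step. Still open, as far as these compounds go, is whether a carboxylic acid, a simple methyl or a longer chain ending in an amine at this nitrogen would give a step beyond the scatter. From the compounds shown here alone, whether the morpholine ring itself matters also remains open.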